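Aryl substituent change on the ring amine of the shared core

A few compounds are considered here, and "the series" means these few. Any claim that something is new, unique, unknown or untested is made for them only; others in the source may bear on it.

Measured compounds:
compound 1 `CCC1(CCCCN2CCN(c3ccc(OC)cc3)CC2)C(=O)Nc2ccccc21` — 25.4 nM
compound 2 `CCC1(CCCCN2CC=C(c3ccc(F)cc3)CC2)C(=O)Nc2ccccc21` — 1.19 nM

In an assay on CHO cells for displacement of a labelled ligand from 5-hydroxytryptamine receptor 7 (Homo sapiens) (a higher number here means a weaker inhibitor, a lower number a stronger inhibitor), compound 1 gives 25.4 nM, the higher of the two numbers; compound 2 gives 1.19 nM, a lower number beyond the scatter. Compound 3 `CCC1(CCCCN2CCN(c3ccccc3Cl)CC2)C(=O)Nc2ccccc21` differs from compound 1 by 2-chlorophenyl in place of 4-methoxyphenyl on an amine nitrogen in a ring. For the measured compounds named here, no measured pair shows this change, so its size is not known from the data. The step from compound 1 to compound 3 is expected to be small, a 1.4-fold lower number from compound 1 to compound 3 (0.15 log units; within the scatter), about within the scatter or slightly toward a lower number. Compound 3 is expected to give 18 nM, between 5 nM and 60 nM.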

Compound 3, inhibition constant: 5.11 nM
Compound 3: the middle estimate sits 3.5-fold (0.55 log units) above what was measured, within the range that was stated.
By their numbers in this assay, from the lowest: compound 2; then compound 3; then compound 1.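

In this assay, 2-chlorophenyl in place of 4-methoxyphenyl on the amine nitrogen in the ring gives a 5.0-fold lower number from compound 1 to compound 3 (0.70 log units; beyond the scatter) on the shared core. For the compounds shown here, this is the first single-place step, and it shows that the aryl group at this position alone can shift the number beyond the scatter. Nothing measured here accounts for the size of this step.

The change swaps both the substituent and where it sits on the phenyl ring, so the two remain unseparated. Open too, going by these compounds, is how an unsubstituted phenyl, 4-chlorophenyl or 2-methoxyphenyl on the same nitrogen would compare.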